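The source may report more compounds than this note shows. Statements on the series, on what has been measured and on what is new or still open speak of the compounds shown alone.

Compound 1 `COc1cc(C(=O)Nc2ccc(C(=O)/C=C/c3nc(C)c(C)nc3C)cc2)cc(OC)c1OC`: 4860 nM
Compound 2 `Cc1nc(C)c(/C=C/C(=O)c2ccc(NC(=O)c3ccccc3F)cc2)nc1C`: 2040 nM

In a functional assay on HepG2 cells (Homo sapiens) for antiproliferative activity, read by CCK-8 assay, with a stated time of 72 h (on this read-out higher numbers stand for weaker inhibition and lower numbers for stronger inhibition), compound 2 gives 2040 nM, the lowest of the two numbers shown, and compound 1 gives 4860 nM, a gap beyond the scatter. Compound 3 `COc1ccc(C(=O)Nc2ccc(C(=O)/C=C/c3nc(C)c(C)nc3C)cc2)cc1OC` carries the change (3,4-dimethoxyphenyl in place of 2-fluorophenyl on a carbonyl carbon). Within the data shown here, no step between measured compounds covers this change. Compound 1, which carries methoxy groups on the same ring, sits at the weaker end. Accordingly the step expected here is a modest weakening, a 1.7-fold higher number from compound 2 to compound 3 (0.23 log units; within the scatter). Compound 3 is therefore estimated at 3500 nM, in a range of 1500 nM to 8000 nM.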

Compound 3, half-maximal inhibitory concentration: 2560 nM
For compound 3 the middle estimate is 1.4-fold (0.14 log units) above the measured one; the measured number falls inside the stated range.
By their numbers in this assay, from the lowest: compounds 2, 3 and 1 (each within the scatter of the next, the first and the last beyond it).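

In this assay, 3,4-dimethoxyphenyl in place of 2-fluorophenyl on a carbonyl carbon gives a 1.3-fold higher number from compound 2 to compound 3 (0.10 log units; within the scatter), so this position takes either aryl group without a change beyond the scatter. Hydrogen in place of methoxy on an aromatic carbon gives a 1.9-fold lower number from compound 1 to compound 3 (0.28 log units; within the scatter), which also stays within the scatter. Nothing available accounts for these results.

The compounds shown leave open whether an unsubstituted phenyl, an amine or a carboxylic acid on this carbonyl carbon would move the number beyond the scatter.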